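A Methyl Added to the Core of a Weak Inhibitor

The compounds below may be only part of what the source reports. "The series", "measured", "known", "first", "only" and "open" are said of these compounds alone.

Two measured compounds share one core and differ only in the end of a short side chain. Compound 1 `CN(CCC(N)=O)C[C@H]1O[C@@H](n2cnc3c(N)ncnc32)[C@H](O)[C@@H]1O` carries a carbamoyl there, and in an assay on isolated protein for inhibition of S-adenosylmethionine decarboxylase proenzyme (Homo sapiens) (a lower number here means a stronger inhibitor, a higher number a weaker inhibitor), compound 1 gives 7000 nM. Compound 2 `CN(CCCN)C[C@H]1O[C@@H](n2cnc3c(N)ncnc32)[C@H](O)[C@@H]1O` carries an aminomethyl instead, and in this assay compound 2 gives 500000 nM. Among the measured compounds shown here, the single step between them, a 71-fold higher number from compound 1 to compound 2 (1.85 log units; beyond the scatter), is the only comparison available. Compound 2 therefore stands at the highest of the two numbers, with compound 1 as its nearest neighbour.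

Compound 3 `Cc1nc2c(N)ncnc2n1[C@@H]1O[C@H](CN(C)CCCN)[C@@H](O)[C@H]1O` keeps the whole of compound 2 and changes the core: methyl in place of hydrogen on an aromatic carbon, on an aromatic carbon of a five-membered aromatic ring with 2 nitrogen, part of a fused system of two rings, between two ring nitrogen atoms, next to the ring atom that bears a large group. For the measured compounds named here, no measured step touches this part of the molecule; the only step known concerns the chain, not the ring. With nothing to lean on, a small step is expected, a 2.0-fold lower number from compound 2 to compound 3 (0.30 log units; within the scatter). Compound 3 is thus estimated at 250000 nM, within 40000 nM to 1000000 nM.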

Compound 3, half-maximal inhibitory concentration: 70000 nM
Estimate against measurement, compound 3: 3.6-fold (0.55 log units) above; the measured number falls inside the stated range.
By their numbers in this assay, from the lowest: compound 1; then compound 3; then compound 2.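

The core turns out to matter in its own right: in this assay, a methyl in place of hydrogen on an aromatic carbon, between two ring nitrogen atoms, gives a 7.1-fold lower number from compound 2 to compound 3 (0.85 log units; beyond the scatter). Among the compounds shown here, the only earlier step lay at the end of the side chain, so this is the first measured sign that the number also responds to a change on the five-membered aromatic ring, while the chain stays the same. The step lies beyond the scatter although the entering group is a single carbon with no hydrogen-bond donors or acceptors, but no measurement on these compounds explains why this methyl has such an effect.

From the compounds shown here alone, whether an ethyl group, an amine or a chlorine atom on this same aromatic carbon would lower the number further, leave it unchanged or raise it remains open, since one group at one position gives no trend. Also open, going by these compounds, is whether the same methyl would give a step of similar size on the carbamoyl chain of compound 1, which is the stronger of the two inhibitors that carry no methyl.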